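The compounds below may be only part of what the source reports. "The series", "measured", "known", "first", "only" and "open" are said of these compounds alone.

Of the compounds shown here, three on a shared core have numbers so far in an ADME assay on MCF7-DOX cells (Homo sapiens) for cytotoxicity, read by MTT assay, with a stated time of 48 h (on this read-out lower numbers stand for stronger inhibition and higher numbers for weaker inhibition), on the same read-out. Compound 1 (`COc1cc(OC)c(C(=O)/C=C/c2cccc(F)c2)c(O)c1CC=C(C)C`) gives 45400 nM and compound 2 (`COc1cccc(/C=C/C(=O)c2c(OC)cc(OC)c(CC=C(C)C)c2O)c1`) gives 49200 nM while compound 3 (`COc1cc(OC)c(C(=O)/C=C/c2cccc(Cl)c2)c(O)c1CC=C(C)C`) gives 59500 nM in the same test. Compound 3 stands within the scatter of both others, with a 1.2-fold higher number from compound 2 to compound 3 (0.08 log units; within the scatter) as its closest gap and a 1.3-fold higher number from compound 1 to compound 3 (0.12 log units; within the scatter) as its widest.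

Compound 4 (`COc1cc(OC)c(C(=O)/C=C/c2cccc(C(F)(F)F)c2)c(O)c1CC=C(C)C`) is compound 3 with trifluoromethyl in place of chloro on an aromatic carbon, meta to a large group (trifluoromethyl in place of chloro on an aromatic carbon) and it has no measured value yet. Going by the values given here, the steps that bear on this change are exchanges at that same place: the two already named, and also a 1.1-fold higher number from compound 1 to compound 2 (0.03 log units; within the scatter) among the remaining pair. All three lie within the scatter, and fluoro, methoxy and chloro at that place are not separated in this assay by these data. Among the compounds with values here, no measured compound carries trifluoromethyl, which leaves the entering group itself untested.

The expectation is thus no step beyond the scatter, in either direction. The estimated move is a 1.1-fold lower number from compound 3 to compound 4 (0.06 log units; within the scatter) and it is expected to stay inside the scatter. For compound 4 the expected value is 52000 nM with an estimated range from 30000 nM to 90000 nM in this test.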

Compound 4, half-maximal inhibitory concentration: 66600 nM
The estimate for compound 4 lay 1.3-fold (0.11 log units) below the measured number; measured number inside the range.
By their numbers in this assay, from the lowest: compounds 1, 2, 3 and 4 (each within the scatter of the next).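

In this assay, going by these compounds alone, trifluoromethyl, the one group at this place that had no number before, does not separate from the three groups already there: the change from chloro gives a 1.1-fold higher number from compound 3 to compound 4 (0.05 log units; within the scatter) while the change from methoxy gives a 1.4-fold higher number from compound 2 to compound 4 (0.13 log units; within the scatter) and the change from fluoro gives a 1.5-fold higher number from compound 1 to compound 4 (0.17 log units; within the scatter) on the same aromatic carbon. The exchange of chloro, with one heavy atom, for trifluoromethyl, with four, thus leaves the result within the scatter, and all four groups now tested at this place remain unresolved from one another in this test. No accompanying measurement bears on this result.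

The compounds shown leave open whether an amine or a carboxylic acid at this place would produce a step beyond the scatter in this assay and so show that the position can respond at all. They also leave open whether a longer chain in place of the chain on the shared core would move the number further than any exchange seen here.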